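Amide-nitrogen exchange from compound 1 to compound 4

This account rests on a few compounds, and the source may have more. Where it says the series, first, only, none or still open, it means among the compounds named here.

Measured in a functional assay on HCT-116 cells (Homo sapiens) for antiproliferative activity, read by MTT assay, with a stated time of 72 h; a lower number here means a stronger inhibitor, a higher number a weaker inhibitor:
compound 1 `Cc1noc(C)c1-c1nn(Cc2ccc(C(=O)NC3CC(C)(C)N([O])C(C)(C)C3)cc2)c(=O)c2ccccc12`: 36800 nM
compound 2 `O=C(Nc1ccccc1Cl)c1ccc(Nc2nn(Cc3ccc(C(=O)NC4CCCCC4)cc3)c(=O)c3ccccc23)cc1`: > 100000 nM
compound 3 `Cn1cc(-c2nn(Cc3ccc(C(=O)NC4CC(C)(C)N([O])C(C)(C)C4)cc3)c(=O)c3ccccc23)cn1`: 50500 nM

Compound 1 has a single numeric neighbour in the set, and the step to it is a 1.4-fold higher number from compound 1 to compound 3 (0.14 log units; within the scatter). Compound 2 gives no number, only a limit of > 100000 nM.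

The next compound is compound 4 `Cc1noc(C)c1-c1nn(Cc2ccc(C(=O)NC3CCCCC3)cc2)c(=O)c2ccccc12`, which keeps the core of compound 1 and changes on an amide-type nitrogen, where cyclohexyl enters: a group of 6 heavy atoms (6 carbon; one six-membered non-aromatic ring of carbon only) in place of a group of 11 heavy atoms (9 carbon, 1 nitrogen, 1 oxygen; one six-membered non-aromatic ring with 1 hetero atom), on an amide-type nitrogen. Among the compounds with values here, the only measured step, a 1.4-fold higher number from compound 1 to compound 3 (0.14 log units; within the scatter), is on an aromatic carbon, so no measured step covers this nitrogen directly. Within the data shown here, compound 2 also carries cyclohexyl on an amide-type nitrogen, but it differs elsewhere and its limit sets no size for the step. In this assay no step beyond the scatter is therefore expected, though with wide uncertainty and a real chance of another limit. The expected step is a 1.5-fold higher number from compound 1 to compound 4 (0.17 log units; within the scatter). For compound 4 the estimated value is 55000 nM, within an expected range of 18000 nM to 100000 nM.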

Compound 4, half-maximal inhibitory concentration: > 100000 nM
Compound 4: a limit, no number; the forecaster's own chance of this, stated with the estimate: 30%; middle value at least 1.8-fold (0.25 log units) away from the limit.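

In this assay, within the data shown here, the amide-type nitrogen is the first place where a single change gives a step beyond the scatter: an at least 2.7-fold higher number from compound 1 to compound 4 (0.43 log units; beyond the scatter). The earlier change on an aromatic carbon stayed within the scatter, a 1.4-fold higher number from compound 1 to compound 3 (0.14 log units; within the scatter), so this nitrogen is the only one of the two changed positions where the read-out responds to the exchange. The value of compound 4, > 100000 nM, is a limit and not a number, so the step has a floor but no measured size: the limit of > 100000 nM in this assay, at which 2 of the 4 values shown sit.

This single pair cannot tell whether the difference follows from losing the ring hetero atom, the attached oxygen or the rest of the larger group. As far as these compounds go, a plain piperidine ring or a longer chain ending in an amine on the amide-type nitrogen remains open as a way of separating these parts.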